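The compounds below may be only part of what the source reports. "The series", "measured", "known", "first", "only" and "open" are said of these compounds alone.

Measured so far in a functional assay on MCF7 cells (Homo sapiens) for cytotoxicity, read by MTT assay, with a stated time of 48 h; on this read-out lower numbers stand for stronger inhibition and higher numbers for weaker inhibition 
- compound 1 `CC1(C)CCCC2=CC=C(C=O)CC[C@]21C` gives 167000 nM 
- compound 2 `C#CC1=CC[C@]2(CC1)C(=C)CC[C@H]2C(C)C` gives 135000 nM 
- compound 3 `C=C1CCC[C@]2(C)CCC(c3cn(-c4ccc(OC)cc4)nn3)=CC[C@@]12C` gives 118000 nM 

Compound 3 (118000 nM) lies within the usual scatter of both compound 1 and compound 2, so the three values cannot be separated. For the measured compounds named here, no two measured compounds differ in one place only, so the series gives no direct reading of any single change.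

Compound 4 `C=C1CCC[C@]2(C)CCC(c3cn(-c4ccc(I)cc4)nn3)=CC[C@@]12C` keeps the core of compound 3 and carries iodo in place of methoxy on an aromatic carbon, para to a large group (iodo in place of methoxy on an aromatic carbon), which turns 4-methoxyphenyl into 4-iodophenyl. The expectation in this assay rests only on compound 3 (118000 nM) and on compound 1 and compound 2 lying within the scatter of it. No step beyond the scatter is expected. The estimated step of a 1.2-fold lower number from compound 3 to compound 4 (0.07 log units; within the scatter) is expected to be small, with a slight lean toward a lower number. For compound 4 the expected value is 100000 nM with an estimated range from 45000 nM to 190000 nM in this measurement.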

Compound 4, half-maximal inhibitory concentration: 162000 nM
For compound 4 the middle estimate is 1.6-fold (0.21 log units) below the measured one, within the range that was stated.
By their numbers in this assay, from the lowest: compounds 3, 2, 4 and 1 (each within the scatter of the next).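

In this assay, for the compounds shown here, iodo in place of methoxy on an aromatic carbon, para to a large group, gives a 1.4-fold higher number from compound 3 to compound 4 (0.14 log units; within the scatter) and so provides the only single-place comparison. The step lies within the usual scatter, so this exchange of 4-methoxyphenyl for 4-iodophenyl, which removes the hydrogen-bond acceptor of the methoxy, does not separate compound 3 from compound 4 on this read-out. No accompanying measurement bears on this result.

Whether any group at this place can shift the number beyond the scatter remains open, since an amine, a carboxylic acid or a longer chain there is not among the compounds shown. Changes elsewhere on the shared core cannot be read, as no other pair differs in one place.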